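This account rests on a few compounds, and the source may have more. Where it says the series, first, only, none or still open, it means among the compounds named here.

In a functional assay on HT-29 cells (Homo sapiens) for antiproliferative activity, read by sulforhodamine B assay, with a stated time of 72 h (a lower number here means a stronger inhibitor, a higher number a weaker inhibitor), compound 1 `COc1ccccc1NC(=S)N/N=C/c1ccc2ccccc2n1` reaches only the assay limit, > 100000 nM, which is a limit and not a number. Compound 3 `NC(=S)N/N=C/c1nc2ccccc2s1` likewise stops at the limit > 100000 nM, again a limit rather than a measured value. Among the measured compounds shown here, compound 2 `NC(=S)N/N=C/c1ccc2cccnc2n1` is the one compound with a measured number, giving 12800 nM. For the measured compounds named here, two of the three values thus sit at the limit of > 100000 nM in this assay, at which 2 of the 3 values shown sit, and no measured step connects compound 1 with any other compound. Compound 4 `Fc1cccc(NC(=S)N/N=C/c2ccc3ccccc3n2)c1` differs from compound 1 by 3-fluorophenyl in place of 2-methoxyphenyl on an amide-type nitrogen. Going by the values given here, no measured pair shows what this change does here, so only a step within the scatter is expected, in either direction an at least 1.1-fold lower number from compound 1 to compound 4 (0.04 log units; that floor lies within the scatter). Compound 4 is therefore estimated at 90000 nM, within 20000 nM to 400000 nM, and most likely reported again only as a limit.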

Compound 4, half-maximal inhibitory concentration: 74700 nM
The estimate for compound 4 lay 1.2-fold (0.08 log units) above the measured number; measured number inside the range.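

In this assay, among the compounds shown here, the change on the amide-type nitrogen gives the first measured number on the core of compound 1, so this position can give a reading short of the assay limit. The step reads an at least 1.3-fold lower number from compound 1 to compound 4 (0.12 log units; that floor lies within the scatter), and only its floor is known, as the comparison rests on a limit: the limit of > 100000 nM in this assay, at which 2 of the 4 values shown sit.

The compounds shown leave open how large the true step is and whether other groups on this nitrogen would move the number further. A plain ethyl chain or an aminophenyl group there remains untested in the compounds shown.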